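Swapping the sulfonamide substituent on compound 2's core

The compounds below may be only part of what the source reports. "The series", "measured", "known", "first", "only" and "open" are said of these compounds alone.

Of the compounds shown here, three with a shared core have been measured in a functional assay on BXPC-3 cells (Homo sapiens) for inhibition, read by MTT assay, with a stated time of 7 days; on this read-out lower numbers stand for stronger inhibition and higher numbers for weaker inhibition. Compound 1 `CCN(CC)S(=O)(=O)c1ccc(S(=O)(=O)N2CCC[C@@H](C(=O)N[C@@H]3CCN(C(=O)OC(C)(C)C)C3)C2)cc1` gives 400 nM, compound 2 `CCCN(CCC)S(=O)(=O)c1ccc(S(=O)(=O)N2CCC[C@@H](C(=O)OCC)C2)cc1` gives 2500 nM, and compound 3 `CCN(CC)S(=O)(=O)c1ccc(S(=O)(=O)N2CCC[C@@H](C(=O)NC)C2)cc1` gives 13800 nM. Among the compounds with values here, the one clean comparison among them, a 35-fold higher number from compound 1 to compound 3 (1.54 log units; beyond the scatter), shows how much the amide substituent matters. Compound 2 holds the second highest number of the three: it sits closer to compound 3 than to compound 1, and both gaps lie beyond the scatter.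

Compound 4 `CCOC(=O)[C@@H]1CCCN(S(=O)(=O)c2ccc(S(=O)(=O)N(C)Cc3ccccc3)cc2)C1` differs from compound 2 in one place: benzyl(methyl)amino in place of dipropylamino on a sulfonyl sulfur. Within the data shown here, no measured pair isolates a change on that sulfonyl sulfur. Compound 1 and compound 3 carry a different group there than compound 2, but they also differ from compound 2 elsewhere, so their values say nothing separable about this change. Among the measured compounds shown here, with no bearing step in hand, the author expects the step of a 1.3-fold lower number from compound 2 to compound 4 (0.10 log units; within the scatter) to stay within the scatter, in no particular direction. The estimate for compound 4 is therefore 2000 nM, with a range from 500 nM to 8000 nM, in this assay.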

Compound 4, half-maximal inhibitory concentration: > 30000 nM
Compound 4: only a limit was reported; the forecaster's own chance of this, stated with the estimate: 5%; middle value at least 15-fold (1.17 log units) from the limit.
By their numbers in this assay, from the lowest: compound 1; then compound 2; then compound 3. At a limit, above all of these: compound 4.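

Within the data shown here, the sulfonyl sulfur, on which no earlier pair bore, turns out to be a sensitive position: in this assay, benzyl(methyl)amino in place of dipropylamino gives an at least 12-fold higher number from compound 2 to compound 4 (1.07 log units; beyond the scatter). The value of compound 4 is a limit and not a number, and it is the only such value among the compounds shown: the limit of > 30000 nM in this assay, at which 1 of the 4 values shown sits. The step therefore fixes only a minimum size for the change, and it shows that a substituent on this sulfur can carry the ethyl ester series from a measurable value in compound 2 to a limit in compound 4.

The change swaps an open chain pair for a six-membered aromatic ring of carbon only together with a methyl, so the compounds shown cannot tell whether the ring or the shorter second substituent goes with the loss; a benzyl(propyl)amino group on the same sulfur would separate the two. Going by these compounds, it also remains open whether the same change holds on the amide compounds, where compound 1 carries diethylamino on this sulfur rather than either group compared here.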